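The source may report more compounds than this note shows. Statements on the series, on what has been measured and on what is new or still open speak of the compounds shown alone.

In a functional assay on MCF7 cells (Homo sapiens) for antiproliferative activity, read by MTT assay, with a stated time of 48 h (a lower number here means a stronger inhibitor, a higher number a weaker inhibitor), three compounds have been measured so far:

compound 1 `O=C(/C=C/c1c[nH]c2ccccc12)c1ccncc1` gives 45300 nM
compound 2 `Cc1ccc(S(=O)(=O)n2cc(/C=C/C(=O)c3ccncc3)c3ccccc32)cc1` gives 48900 nM
compound 3 `O=C(/C=C/c1cn(S(=O)(=O)c2cccc([N+](=O)[O-])c2)c2ccccc12)c1ccncc1` gives 36300 nM

Compound 2 cannot be separated from the other two on these numbers, as its value lies within the scatter of both compound 1 and compound 3. The three values stay close together although compound 1 carries no sulfonyl group, while compound 2 and compound 3 do.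

Compound 4 `COc1ccc(S(=O)(=O)n2cc(/C=C/C(=O)c3ccncc3)c3ccccc32)cc1` has not yet been measured. It differs from compound 2 in one place: methoxy in place of methyl on an aromatic carbon. This is methoxy in place of methyl on an aromatic carbon, para to a large group, so that 4-methylphenyl becomes 4-methoxyphenyl.

Among the measured compounds shown here, only one measured step changes the group on the sulfonyl sulfur, where 3-nitrophenyl takes the place of 4-methylphenyl. For the measured compounds named here, no measured step tests methoxy itself, so the evidence is indirect. Going by the values given here, with a 1.3-fold lower number from compound 2 to compound 3 (0.13 log units; within the scatter) as the only guide at this group, no step beyond the scatter is expected in this assay, in either direction. The estimate amounts to an expected 1.1-fold lower number from compound 2 to compound 4 (0.04 log units; within the scatter). For compound 4 the estimated value is 45000 nM, with an expected range from 25000 nM to 80000 nM.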

Compound 4, half-maximal inhibitory concentration: 65800 nM
Compound 4: the middle estimate sits 1.5-fold (0.17 log units) below what was measured, within the range that was stated.
By their numbers in this assay, from the lowest: compounds 3, 1, 2 and 4 (each within the scatter of the next).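

In this assay, the change from methyl to methoxy on the aromatic carbon gives a 1.3-fold higher number from compound 2 to compound 4 (0.13 log units; within the scatter). Among the compounds shown here, this is the first direct reading at that carbon, and bringing in the oxygen and the hydrogen-bond acceptor that methoxy counts produces no step that can be told from the scatter. The comparison on the sulfonyl sulfur gives a 1.8-fold higher number from compound 3 to compound 4 (0.26 log units; within the scatter), so 4-methylphenyl, 3-nitrophenyl and 4-methoxyphenyl now form a set of three groups there with no listed step between them beyond the scatter, and no separate measurement bears on why these numbers stay so close.

On these data alone, it remains open whether any group on this aromatic carbon can move the number beyond the scatter, for instance an amine, a carboxylic acid or a longer chain such as butoxy in place of methoxy. All the compounds shown also keep the same shared core, so they say nothing about how a change within that core would read in this assay and whether such a change would matter more than the group on the sulfonyl sulfur.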